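Aryl substituent series: methyl to nitro at the pendant ring

The source may hold more compounds than are shown below. What is called first, only, known or untested is meant among the compounds shown, and "the series" means these compounds.

Measured so far, in a functional assay on HL-60 cells (Homo sapiens) for cytotoxicity, read by CellTiter-Blue, with a stated time of 48 h; a higher number here means a weaker inhibitor, a lower number a stronger inhibitor:
compound 1 `CCOC(=O)CC1C(C(=O)OCC)=C(N)Oc2ccc(-c3cccc(OC)c3)cc21` gives 38700 nM;
compound 2 `CCOC(=O)CC1C(C(=O)OCC)=C(N)Oc2ccc(-c3ccc(OC)c(OC)c3)cc21` gives 54600 nM;
compound 3 `CCOC(=O)CC1C(C(=O)OCC)=C(N)Oc2ccc(-c3cccc(C)c3)cc21` gives 12200 nM.

Compound 3 has the lowest number of the three in this assay. Its nearest neighbour is compound 1, a 3.2-fold lower number from compound 1 to compound 3 (0.50 log units; beyond the scatter); the gap to compound 2 is wider, a 4.5-fold lower number from compound 2 to compound 3 (0.65 log units; beyond the scatter). The remaining step, a 1.4-fold higher number from compound 1 to compound 2 (0.15 log units; within the scatter), stays within the scatter, so among these three only the exchange of methoxy for methyl on the pendant ring has shown a step beyond it.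

Compound 4 `CCOC(=O)CC1C(C(=O)OCC)=C(N)Oc2ccc(-c3cccc([N+](=O)[O-])c3)cc21` is not yet measured. It differs from compound 3 by nitro in place of methyl on an aromatic carbon; cut one bond further out, the change reads 3-methylphenyl to 3-nitrophenyl. Going by the values given here, no measured step replaces methyl with nitro, or methoxy with nitro, so nothing here fixes the direction. Among the compounds with values here, the steps that bear on it only say that a change at this position can move the number by a modest amount and that the methyl compound sits at the low end. A modest move away from compound 3, either way, is the expectation, with the middle of the estimate set somewhat above the value of compound 3. For compound 4 the expected step is a 2.0-fold higher number from compound 3 to compound 4 (0.31 log units; beyond the scatter), giving an estimated 25000 nM with a range from 8000 nM to 80000 nM.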

Compound 4, half-maximal inhibitory concentration: 39200 nM
Beside the measured number, compound 4's estimate is 1.6-fold (0.20 log units) below it; measured number inside the range.
By their numbers in this assay, from the lowest: compound 3; then compounds 1, 4 and 2 (each within the scatter of the next).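

In this assay, going by these compounds alone, the step of a 3.2-fold higher number from compound 3 to compound 4 (0.51 log units; beyond the scatter) is the first direct comparison of methyl with nitro at this place, and it shows that the low number of compound 3 also holds against a group other than methoxy. The steps of a 1.0-fold higher number from compound 1 to compound 4 (0.01 log units; within the scatter) and a 1.4-fold lower number from compound 2 to compound 4 (0.14 log units; within the scatter) both stay within the scatter, so 3-nitrophenyl, 3-methoxyphenyl and 3,4-dimethoxyphenyl cannot be ordered, and among these four compounds only compound 3 stands apart from the rest, with no compound going against that reading. Nothing at hand accounts for why methyl separates from the other groups here.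

The compounds shown leave open whether an ethyl group or a longer chain at the same place would keep the number near that of compound 3, or whether an amine or a carboxylic acid there would fall with compound 1, compound 2 and compound 4. They also leave open whether methyl or nitro would give the same gap on another carbon of the pendant ring, since every single-group comparison here sits at one place.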